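Transferring the side-chain removal to a second core

The source may report more compounds than this note shows. Statements on the series, on what has been measured and on what is new or still open speak of the compounds shown alone.

Compound 1 `CC(C)(c1cc([C@@]23CCOC[C@@H]2C3)nc(-c2cccc(O)c2)n1)S(C)(=O)=O` carries a 1-methyl-1-(methylsulfonyl)ethyl group on its core; in a physicochemical assay for lipophilicity (a higher number here means a more lipophilic compound, a lower number a more polar compound), compound 1 gives 4.8. Compound 2 `Oc1cccc(-c2nccc([C@@]34CCOC[C@@H]3C4)n2)c1` lacks that group, and in this assay compound 2 gives 4. The change between them, (hydrogen in place of 1-methyl-1-(methylsulfonyl)ethyl on an aromatic carbon), produces a number 0.80 log units lower from compound 1 to compound 2 (beyond the scatter).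

Compound 3 `CCNC(=O)Nc1ccc(-c2nc(C(C)(C)S(C)(=O)=O)cc([C@@]34CCOC[C@@H]3C4)n2)cc1` carries the same group on a different core; the difference between the core of compound 3 and the core of compound 1 is not broken down here. In this assay compound 3 gives 4.7; its value and that of compound 1 lie within the usual scatter of each other, while compound 2 lies lower, beyond the scatter.

Compound 4 `CCNC(=O)Nc1ccc(-c2nccc([C@@]34CCOC[C@@H]3C4)n2)cc1` is the unmeasured partner of compound 3. The change hydrogen in place of 1-methyl-1-(methylsulfonyl)ethyl on an aromatic carbon is the same kind of change as that from compound 1 to compound 2, though here the place is described as meta to a group of 7 heavy atoms and meta to a large group rather than meta to a 3-hydroxyphenyl group (7 heavy atoms). The step from compound 3 to compound 4 in this assay is expected to be a number 0.80 log units lower from compound 3 to compound 4 (beyond the scatter). This expectation rests on the measured step of a number 0.80 log units lower from compound 1 to compound 2 (beyond the scatter) for the same kind of change. Compound 4 is therefore expected to give 3.9 in this assay, estimated to fall between 3.4 and 4.4.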

Compound 4, partition coefficient: 3.9
The estimate for compound 4 equals the measured number at the digits printed; the range from low to high includes it.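

In this assay the replacement of 1-methyl-1-(methylsulfonyl)ethyl by hydrogen gives a number 0.80 log units lower from compound 3 to compound 4 (beyond the scatter) and, on the other core, a number 0.80 log units lower from compound 1 to compound 2 (beyond the scatter) as well; the two steps have the same direction and the same size at the printed digits, and on these two pairs the change carries from one core to the other. This rests on two pairs only, with the change at the same place in both, and it does not show that the step would keep its size on any further core in the series. Nothing available bears on what sets the size of this step.

Open, on these data alone, is whether a methyl group, an amine or a carboxylic acid in place of 1-methyl-1-(methylsulfonyl)ethyl on that aromatic carbon would also give matching steps on both cores. Also open, as far as these compounds go, is whether a longer chain carrying the same methylsulfonyl end would behave alike on the two cores.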